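The source may hold more compounds than are shown below. What is called first, only, known or untested is meant among the compounds shown, and "the series" means these compounds.

In a functional assay on HepG2 cells (Homo sapiens) for inhibition, read by fluorescence and resazurin assay, with a stated time of 72 h (a lower number here means a stronger inhibitor, a higher number a weaker inhibitor), compound 1 `O=S(=O)(c1ccc(Nc2nccc(Nc3ccc4nc[nH]c4c3)n2)cc1)N1CCOCC1` reaches only a limit of the assay, > 25000 nM. Among the compounds with values here, compound 2 `O=C(Nc1ccccc1)Nc1cccc(Nc2nccc(Nc3ccc4nc[nH]c4c3)n2)c1` gives 11000 nM, the only true number so far, so its standing cannot yet be judged against another measured value. Compound 3 `O=C(Nc1ccccc1)Nc1cccc(Nc2nccc(Nc3ccc4cn[nH]c4c3)n2)c1` has the same atoms as compound 2, joined differently, with 1H-indazol-6-yl in place of 1H-benzimidazol-6-yl on a nitrogen on an aromatic ring. Within the data shown here, no measured pair shows what this swap does, so no clear direction can be expected. The expected change, a 1.1-fold lower number from compound 2 to compound 3 (0.04 log units; within the scatter), stays within the usual scatter. For compound 3 the estimated value is 10000 nM, with an expected range from 3500 nM to 25000 nM.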

Compound 3, half-maximal inhibitory concentration: 8200 nM
The estimate for compound 3 lay 1.2-fold (0.09 log units) above the measured number; low and high end bracket the measured number.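

Putting 1H-indazol-6-yl in place of 1H-benzimidazol-6-yl on the nitrogen gives a 1.3-fold lower number from compound 2 to compound 3 (0.13 log units; within the scatter) in this assay, so the two groups cannot be told apart here. Within the data shown here, this is the first comparison of two true numbers at this position, and it shows that this exchange of one group for the other, with the same atoms joined differently, leaves the result unchanged within the scatter. Only one compound shown stands at a limit rather than a number: the limit of > 25000 nM in this assay, at which 1 of the 3 values shown sits.

Still open, as far as these compounds go, is whether a different group on this nitrogen, such as a plain phenyl ring or a phenyl ring carrying a carboxylic acid or an amine, would shift the number beyond the scatter.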